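The source may hold more compounds than are shown below. What is called first, only, known or untested is meant among the compounds shown, and "the series" means these compounds.

Compound 2 `Cc1nnc(CN2CCCC2)n1-c1ccc(Cl)cc1C(=O)c1ccccc1Cl` gives 4 mg/kg in a functional assay on the whole organism (strain CF-1) for inhibition, with Mus musculus as the target; on this read-out higher numbers stand for an effect only at larger amounts of compound and lower numbers for an effect already at smaller amounts. Among the compounds with values here, of the two numbers known here, that of compound 2 is the smaller, yet compound 1 `Cc1nnc(CN(C)C)n1-c1ccccc1C(=O)c1ccccc1Cl`, which gives 7 mg/kg in this assay, lies within the scatter of it, so the two cannot be told apart. Compound 3 `Cc1nnc(CN(C)C)n1-c1ccc(Cl)cc1C(=O)c1ccccc1Cl` differs from compound 2 in one place: dimethylamino in place of pyrrolidin-1-yl on a saturated chain carbon bound to an aromatic carbon. Compound 3 thus shares the dimethylamino of compound 1 but otherwise matches compound 2. Within the data shown here, no measured pair isolates this change, so the step of a 1.3-fold higher number from compound 2 to compound 3 (0.10 log units; within the scatter) is expected to be none beyond the scatter. Compound 3 is expected to give 5 mg/kg, within a range from 2 mg/kg to 12 mg/kg.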

Compound 3, dose for half-maximal effect: 0.28 mg/kg
For compound 3 the middle estimate is 18-fold (1.25 log units) above the measured one, outside the stated range (below it).
By their numbers in this assay, from the lowest: compound 3; then compounds 2 and 1 (each within the scatter of the next).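

Dimethylamino in place of pyrrolidin-1-yl on a saturated chain carbon bound to an aromatic carbon gives a 14-fold lower number from compound 2 to compound 3 (1.15 log units; beyond the scatter) in this assay and so is far from a neutral swap. Chloro in place of hydrogen on an aromatic carbon gives a 25-fold lower number from compound 1 to compound 3 (1.40 log units; beyond the scatter) on the same read-out, so each single change matters well beyond the scatter. Nothing measured here accounts for either step. Still open, from the compounds shown here alone, is whether another amine, such as diethylamino or piperidin-1-yl, would hold the number of compound 3, and whether fluoro or bromo could replace the chloro.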